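Pyrazolyl chalcone series: dichlorophenyl variant of compound 1

The source may report more compounds than this note shows. Statements on the series, on what has been measured and on what is new or still open speak of the compounds shown alone.

Compound 1 `COc1cc(-c2cc(/C=C/C(=O)c3ccc(N)cc3)[nH]n2)cc(OC)c1OC` gives 1360 nM in a functional assay on UO-31 cells (Homo sapiens) for inhibition, read by sulforhodamine B assay, with a stated time of 48 h; on this read-out higher numbers stand for weaker inhibition of growth and lower numbers for stronger inhibition of growth. Its number is the higher of the two measured, but compound 2 `COc1ccc(-c2cc(/C=C/C(=O)c3ccc(OC)c(OC)c3)[nH]n2)cc1`, which gives 1170 nM in this assay, lies within the scatter of compound 1, so the two cannot be told apart. Compound 3 `COc1cc(-c2cc(/C=C/C(=O)c3ccc(Cl)c(Cl)c3)[nH]n2)cc(OC)c1OC` is not yet measured. It differs from compound 1 in one place: 3,4-dichlorophenyl in place of 4-aminophenyl on a carbonyl carbon. Among the compounds with values here, no measured pair shows this change, so its direction is unknown; the step from compound 1 to compound 3 is expected to be small, a 1.1-fold higher number from compound 1 to compound 3 (0.04 log units; within the scatter), likely not beyond the scatter. Compound 3 is estimated at 1500 nM, with a range from 500 nM to 5000 nM.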

Compound 3, concentration for 50% growth inhibition: 5730 nM
For compound 3 the middle estimate is 3.8-fold (0.58 log units) below the measured one; the measured number lies above the stated range.
By their numbers in this assay, from the lowest: compounds 2 and 1 (each within the scatter of the next); then compound 3.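

On the carbonyl carbon, the aryl group matters in this assay: 3,4-dichlorophenyl in place of 4-aminophenyl gives a 4.2-fold higher number from compound 1 to compound 3 (0.62 log units; beyond the scatter), meaning weaker inhibition of growth. Within the data shown here, this is the first single-place step, so the earlier compounds gave no reading of this position. No measurement on hand accounts for the step.

Open, from the compounds shown here alone, is whether the change follows from losing the amine or from gaining the chlorines. A plain phenyl or a monochlorophenyl on the same carbon would separate the two.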